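Replacing a Dichlorophenyl with a Methoxyphenyl on the Ring Nitrogen

This account rests on a few compounds, and the source may have more. Where it says the series, first, only, none or still open, it means among the compounds named here.

Three compounds sharing one core were tested in a functional assay on the whole organism (strain Kunming) for inhibition, with Mus musculus as the target, with a stated time of 1 h, at a dose of 40 mg/kg by the oral route; on this read-out lower numbers stand for less inhibition and higher numbers for more inhibition at the one dose given (going by the name of the read-out). Compound 1 `O=C(/C=C/c1ccccc1)c1ccc(N2CCN(c3ccc([N+](=O)[O-])cc3)CC2)cc1` gives 55.4%. Compound 2 `Cc1ccc(N2CCN(c3ccc(C(=O)/C=C/c4ccccc4)cc3)CC2)c(C)c1` gives 15%, and compound 3 `O=C(/C=C/c1ccccc1)c1ccc(N2CCN(c3cccc(Cl)c3Cl)CC2)cc1` gives 30.7%. Compound 3 therefore stands second highest of the three: the step of a number 24.7 percentage points lower from compound 1 to compound 3 (beyond the scatter) lowered the reading, while the step of a number 15.7 percentage points higher from compound 2 to compound 3 (beyond the scatter) raised it. Both of these steps altered only the group on the amine nitrogen in a ring, and both were beyond the scatter, so this place clearly matters for the reading.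

Compound 4 `COc1cccc(N2CCN(c3ccc(C(=O)/C=C/c4ccccc4)cc3)CC2)c1` has not yet been measured. It differs from compound 3 in one place: 3-methoxyphenyl in place of 2,3-dichlorophenyl on an amine nitrogen in a ring. For the measured compounds named here, no measured step involves 3-methoxyphenyl, so its direction cannot be read from the earlier steps; those steps only show that changes at the amine nitrogen in a ring moved the reading by modest to large amounts. Compound 4 is expected to give about 32%, within a range from 12% to 55%. The expected step is a number 1.3 percentage points higher from compound 3 to compound 4 (within the scatter), estimated to remain within the scatter.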

Compound 4, a percentage reported as inhibition, in the whole organism at one dose (the size of the read-out at that dose, not a potency): 16%
Compound 4: middle estimate off by 16 percentage points, on the high side, and the stated range covers the measured number.
By their numbers in this assay, from the lowest: compounds 2 and 4 (each within the scatter of the next); then compound 3; then compound 1.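

In this assay, 3-methoxyphenyl on the amine nitrogen in a ring is not interchangeable with 2,3-dichlorophenyl, even though both groups have the same count of heavy atoms: the change gives a number 14.7 percentage points lower from compound 3 to compound 4 (beyond the scatter). Against the 4-nitrophenyl group the change gives a number 39.4 percentage points lower from compound 1 to compound 4 (beyond the scatter), which leaves compound 1 with the highest reading of the four, while the comparison with 2,4-dimethylphenyl gives a number 1 percentage points higher from compound 2 to compound 4 (within the scatter), so these two quite different groups cannot be told apart at this dose. No measurement on hand explains why these groups differ.

The compounds shown do not reveal whether the reading depends on where the methoxy group sits, as 4-methoxyphenyl would test. They also leave open how an unsubstituted phenyl, a pyridine ring or a benzyl group would behave on this nitrogen.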